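Benzyl in Place of Pentan-3-yl on the Ring Amine

A few compounds are considered here, and "the series" means these few. Any claim that something is new, unique, unknown or untested is made for them only; others in the source may bear on it.

Compound 1 `COc1cc(N)c(Cl)cc1NC(=O)C1CCN(CC2CCC2)CC1`, compound 2 `COc1cc(N)c(Cl)cc1NC(=O)C1CCN(CC2CCCC2)CC1` and compound 3 `CCC(CC)CN1CCC(C(=O)Nc2cc(Cl)c(N)cc2OC)CC1` share one core and differ only in the group on a saturated chain carbon bound to an amine nitrogen in a ring. In a functional assay on the whole organism for antagonist activity, with Mus musculus as the target (on this read-out higher numbers stand for an effect only at larger amounts of compound and lower numbers for an effect already at smaller amounts), compound 1 reaches only the limit > 10 mg/kg. Compound 2 likewise stops at the limit > 10 mg/kg in this assay. Compound 3 also gives only the limit > 10 mg/kg in this assay, so its standing among these three cannot be ranked. The steps a step that the two limits leave unreadable from compound 1 to compound 2, a step that the two limits leave unreadable from compound 1 to compound 3 and a step that the two limits leave unreadable from compound 2 to compound 3 stay unreadable because of the limit of > 10 mg/kg in this assay, at which 3 of the 3 values shown sit. Compound 4 `COc1cc(N)c(Cl)cc1NC(=O)C1CCN(Cc2ccccc2)CC1` brings (phenyl in place of pentan-3-yl on a saturated chain carbon bound to an amine nitrogen in a ring). Going by the values given here, no measured step involves an aromatic group, so none bears directly on this change. Compound 4 is expected near 10 mg/kg, within 3 mg/kg to 30 mg/kg. This expectation corresponds to the step of a number no higher from compound 3 to compound 4 (the limit leaves the size open), quite possibly again only a limit.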

Compound 4, dose for half-maximal effect: 0.5 mg/kg
Estimate against measurement, compound 4: 20-fold (1.30 log units) above; the whole stated range lies above it.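

Phenyl gives an at least 20-fold lower number from compound 3 to compound 4 (1.30 log units; beyond the scatter) and an at least 20-fold lower number from compound 2 to compound 4 (1.30 log units; beyond the scatter) and an at least 20-fold lower number from compound 1 to compound 4 (1.30 log units; beyond the scatter) in this assay at this position on a saturated chain carbon bound to an amine nitrogen in a ring. The position therefore does respond to the group it carries, and pentan-3-yl, cyclopentyl and cyclobutyl all stand apart from phenyl. The steps among compound 1, compound 2 and compound 3 remain unreadable: the limit of > 10 mg/kg in this assay, at which 3 of the 4 values shown sit. As far as these compounds go, whether a pyridyl ring or a fluorophenyl group would match phenyl stays open, as does the effect of a longer chain between the aromatic ring and the amine nitrogen.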